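From Acetyl to Formyl: an Expected Small Step

The source may report more compounds than this note shows. Statements on the series, on what has been measured and on what is new or still open speak of the compounds shown alone.

Three compounds have been measured:
compound 1 `CC(=O)c1ccc2c(c1)C(n1ccccc1=O)=CC(C)(C)O2` with 6.65
compound 2 `COc1ccc(C(=O)c2ccc3c(c2)C(n2ccccc2=O)=CC(C)(C)O3)cc1` with 5.72
compound 3 `CC1(C)C=C(n2ccccc2=O)c2cc(C(=O)c3ccccc3[N+](=O)[O-])ccc2O1` with 5.64

In a functional assay (trachea) with Rattus norvegicus as the target (a higher number here means a more potent compound, by a factor of ten per unit of this negative logarithm, a lower number a less potent compound), compound 1 stands highest of the three; the steps of a number 0.93 log units lower from compound 1 to compound 2 (beyond the scatter) and a number 1.01 log units lower from compound 1 to compound 3 (beyond the scatter) both lie beyond the scatter, while a number 0.08 log units lower from compound 2 to compound 3 (within the scatter) does not. Compound 4 `CC1(C)C=C(n2ccccc2=O)c2cc(C=O)ccc2O1` differs from compound 1 by hydrogen in place of methyl on a carbonyl carbon. Among the compounds with values here, both measured steps replaced the methyl on the carbonyl carbon with a larger aryl group and lowered potency; no measured step replaces it with hydrogen, so they bear on the new step only loosely. The change is expected to cost little or nothing beyond the scatter, giving the estimated step of a number 0.30 log units lower from compound 1 to compound 4 (within the scatter). Compound 4 is therefore estimated at 6.35, likely between 5.7 and 7.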

Compound 4, logarithm of the reciprocal of the active concentration, log(1/C): 6.14
The estimate for compound 4 lay 0.21 log units above the measured number, within the range that was stated.
By their numbers in this assay, from the lowest: compounds 3 and 2 (each within the scatter of the next); then compound 4; then compound 1.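

Hydrogen in place of methyl also lowers the number (a number 0.51 log units lower from compound 1 to compound 4 (beyond the scatter)), so at this carbonyl carbon the loss is not confined to swaps for larger aryl groups. Hydrogen still stands above both aryl groups (a number 0.50 log units higher from compound 3 to compound 4 (beyond the scatter); a number 0.42 log units higher from compound 2 to compound 4 (beyond the scatter)), which places formyl between acetyl and the two aryl ketones, with methyl the best of the four substituents. No measurement at hand gives a reason for this order.

As far as these compounds go, whether a slightly longer chain such as ethyl would match or pass methyl on this carbonyl carbon stays open, as does the effect of an amine there, which would give an amide.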